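The source may report more compounds than this note shows. Statements on the series, on what has been measured and on what is new or still open speak of the compounds shown alone.

Compound 1 (`CO[C@H]1CC[C@H](Nc2cc(NCc3cnccc3C(F)(F)F)ncc2C#N)CC1`) was tested in an assay on isolated protein for inhibition of protein kinase C delta type (Homo sapiens), read by TR-FRET, with a stated time of 2 h; a higher number here means a weaker inhibitor, a lower number a stronger inhibitor. In this assay compound 1 gives only > 10000 nM, and that is a limit of the assay rather than a number: the limit of > 10000 nM in this assay, at which 1 of the 2 values shown sits. Where compound 1 stands among the values shown therefore cannot be pinned down more closely than that. A second compound, compound 2 (`N#Cc1cnc(NCc2cncnc2C(F)(F)F)cc1N[C@H]1CC[C@@H](O)CC1`), was also measured, and in this assay compound 2 gives 450 nM. For the measured compounds named here, compound 2 differs from compound 1 in more than one place, so no single step can be read between them; the two values show only that compound 2 yields a number while compound 1 yields a limit.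

The compound still to be measured is compound 3 (`CC1(C)[C@H](Nc2cc(NCc3cnccc3C(F)(F)F)ncc2C#N)C[C@H]1C(N)=O`). It differs from compound 1 in one place: 3-carbamoyl-2,2-dimethylcyclobutyl in place of 4-methoxycyclohexyl on a nitrogen on an aromatic ring. Going by the values given here, no measured step of this kind exists here. The step from compound 1 to compound 3 is expected to be an at least 3.3-fold lower number from compound 1 to compound 3 (0.52 log units; beyond the scatter), that is, toward stronger inhibition and larger than the usual scatter, because compound 1 sits at the limit of > 10000 nM in this assay, at which 1 of the 2 values shown sits, and any number at all would lie below it. Compound 3 is expected to give about 3000 nM, somewhere between 400 nM and 12000 nM.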

Compound 3, half-maximal inhibitory concentration: 900 nM
Compound 3: the middle estimate sits 3.3-fold (0.52 log units) above what was measured; the range from low to high includes it.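

On a nitrogen on an aromatic ring, putting 3-carbamoyl-2,2-dimethylcyclobutyl in place of 4-methoxycyclohexyl gives, in this assay, an at least 11-fold lower number from compound 1 to compound 3 (1.04 log units; beyond the scatter). For the compounds shown here, this is the first single change that can be read at this position, as compound 1 and compound 2 differ in more than one place, and it shows that changing this group alone, with the rest of compound 1 kept, is enough to turn a limit into a measured number. The full size of the step cannot be read because the value of compound 1 is only a limit: the limit of > 10000 nM in this assay, at which 1 of the 3 values shown sits.

The change replaces the ring, adds the dimethyl groups and brings in the carbamoyl group all at once, so the compounds shown cannot tell which of these parts accounts for the step. As far as these compounds go, it also remains open whether a carboxylic acid in place of the carbamoyl group, or a plain cyclobutyl ring without the dimethyl groups, would keep the lower number, and whether the same group would have a similar effect on the core of compound 2.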